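The source may hold more compounds than are shown below. What is called first, only, known or untested is meant among the compounds shown, and "the series" means these compounds.

Measured in a functional assay on CAPAN-1 cells (Homo sapiens) for antiproliferative activity, with a stated time of 72 h; a lower number here means a stronger inhibitor, a higher number a weaker inhibitor:
- Compound 1 `Nc1ncnn2c([C@@H]3O[C@H](CO)[C@@H](O)[C@H]3O)cc(C#Cc3cccs3)c12`: 32000 nM
- Compound 2 `Cc1ccccc1-c1cc([C@@H]2O[C@H](CO)[C@@H](O)[C@H]2O)n2ncnc(N)c12`: 97500 nM

Of these two, compound 2 has the higher number, 97500 nM, which makes it the weaker inhibitor. Compound 3 `Nc1ncnn2c([C@@H]3O[C@H](CO)[C@@H](O)[C@H]3O)cc(/C=C/c3ccccc3)c12` has not yet been measured. It keeps the shared core and has 2-phenylethenyl in place of 2-methylphenyl on an aromatic carbon.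

Among the measured compounds shown here, only one measured step bears on this change: a 3.0-fold higher number from compound 1 to compound 2 (0.48 log units; beyond the scatter). That step, 2-methylphenyl in place of 2-(thiophen-2-yl)ethynyl on an aromatic carbon, is modest but beyond the scatter. Like compound 1, compound 3 carries its ring on a linker rather than directly on the core. The expected change in this assay is therefore a modest one toward a lower number, a 2.6-fold lower number from compound 2 to compound 3 (0.41 log units; beyond the scatter). With a single step as evidence, the expected range is wide. For compound 3 the estimated value is 38000 nM, expected between 12000 nM and 100000 nM.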

Compound 3, half-maximal inhibitory concentration: 2600 nM
Compound 3: the middle estimate sits 15-fold (1.16 log units) above what was measured; the measured number lies below the stated range.
By their numbers in this assay, from the lowest: compound 3; then compound 1; then compound 2.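

The earlier pair showed only a modest spread, but in this assay the group on this aromatic carbon can shift the number much further: 2-phenylethenyl in place of 2-methylphenyl gives a 38-fold lower number from compound 2 to compound 3 (1.57 log units; beyond the scatter) and in place of 2-(thiophen-2-yl)ethynyl gives a 12-fold lower number from compound 1 to compound 3 (1.09 log units; beyond the scatter) at the same position. A ring on a linker is therefore not enough on its own to reach the lowest number here, as compound 1 also has one, although its step changes both the linker and the ring and cannot show which of the two matters. Nothing measured here explains the size of these steps.

Going by these compounds, it remains open whether 2-phenylethynyl, with the triple bond of compound 1 and the ring of compound 3, would stand closer to compound 1 or compound 3. Also open, on these data alone, is how an amine or a carboxylic acid on the phenyl ring of compound 3 would change the number.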